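Capping the Free Hydroxyl of Compound 3 with Phosphate

This account rests on a few compounds, and the source may have more. Where it says the series, first, only, none or still open, it means among the compounds named here.

Compound 1, `COCCc1cn(-c2ccc(NC(=O)Nc3ccccc3C)cc2)nn1`, gives 1000 nM in an assay on isolated protein for inhibition of ATP-dependent RNA helicase DDX3X (Homo sapiens), read by FRET, with stated times of 30 s and 40 min; a higher number here means a weaker inhibitor, a lower number a stronger inhibitor.
Compound 2, `Cc1ccccc1NC(=O)Nc1ccc(-n2cc(CCCN(C)C)nn2)cc1`, gives 2900 nM.
Compound 3, `Cc1ccccc1NC(=O)Nc1ccc(-n2cc(CCO)nn2)cc1`, gives 13000 nM.

Compound 3 has the highest number of the three and is the weakest inhibitor here: a 4.5-fold higher number from compound 2 to compound 3 (0.65 log units; beyond the scatter), and a 13-fold higher number from compound 1 to compound 3 (1.11 log units; beyond the scatter).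

Compound 4, `CCOP(=O)(OCC)OCCc1cn(-c2ccc(NC(=O)Nc3ccccc3C)cc2)nn1`, differs from compound 3 by a group of 8 heavy atoms (4 carbon, 3 oxygen, 1 phosphorus; no ring) in place of a hydrogen atom, on an oxygen on a saturated carbon. The step that bears on this is a 13-fold higher number from compound 1 to compound 3 (1.11 log units; beyond the scatter), where uncovering that oxygen weakened inhibition greatly; compound 4 covers the same oxygen again. A lower number is therefore expected for compound 4, but the entering group is much larger than methyl and unlike anything measured, so the expected step of a 5.2-fold lower number from compound 3 to compound 4 (0.72 log units; beyond the scatter) is set below that earlier step. Compound 4 is estimated at 2500 nM, within 700 nM to 9000 nM.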

Compound 4, half-maximal inhibitory concentration: 890 nM
Beside the measured number, compound 4's estimate is 2.8-fold (0.45 log units) above it; measured number inside the range.
By their numbers in this assay, from the lowest: compounds 4 and 1 (each within the scatter of the next); then compound 2; then compound 3.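

Capping this oxygen does not depend on a small group: with a 15-fold lower number from compound 3 to compound 4 (1.16 log units; beyond the scatter) the much larger phosphorus-bearing cap restores inhibition, and with a 1.1-fold lower number from compound 1 to compound 4 (0.05 log units; within the scatter) it cannot be told apart from methyl. The same cap also compares well with the amine chain, with a 3.3-fold lower number from compound 2 to compound 4 (0.51 log units; beyond the scatter) on the same side chain. Nothing measured here explains why the two different caps read alike.

From the compounds shown here alone, it remains open whether an ethyl or acetyl cap on this oxygen would read the same. A longer chain carrying the methoxy group is also untested ground in these compounds.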